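Trading Chloro for Trifluoromethyl: an Expected Cytotoxicity Outcome

The compounds below may be only part of what the source reports. "The series", "measured", "known", "first", "only" and "open" are said of these compounds alone.

Compound 1 `O=C(CSC(=S)N[C@H]1CCOC1=O)Nc1ccc(Br)cc1` — 67400 nM
Compound 2 `O=C(CSC(=S)N[C@H]1CCOC1=O)Nc1cccc(Cl)c1` — 107000 nM
Compound 3 `Cc1ccc(NC(=O)CSC(=S)N[C@H]2CCOC2=O)cc1` — 93900 nM

In a functional assay on EC9706 cells (Homo sapiens) for cytotoxicity, read by MTT assay, with a stated time of 72 h (on this read-out higher numbers stand for weaker inhibition and lower numbers for stronger inhibition), compound 2 gives the highest of the three numbers, yet its steps to the others are small: a 1.1-fold lower number from compound 2 to compound 3 (0.06 log units; within the scatter), and the earlier step of a 1.6-fold higher number from compound 1 to compound 2 (0.20 log units; within the scatter). The third measured step, a 1.4-fold higher number from compound 1 to compound 3 (0.14 log units; within the scatter), is likewise within the scatter, so across these three compounds the substituent on the ring makes no detectable difference.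

Compound 4 `O=C(CSC(=S)N[C@H]1CCOC1=O)Nc1cccc(C(F)(F)F)c1` is not yet measured. Among the measured compounds shown here, its only change from compound 2 is trifluoromethyl in place of chloro on an aromatic carbon. For the measured compounds named here, no measured step exchanges chloro for trifluoromethyl at this place, so the nearest guidance comes from the steps above, all of which show that swapping one small ring substituent for another leaves this assay essentially unchanged. The expected step is therefore a 1.1-fold lower number from compound 2 to compound 4 (0.03 log units; within the scatter), that is, none beyond the scatter. Compound 4 is estimated at 100000 nM, with a range from 40000 nM to 250000 nM.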

Compound 4, half-maximal inhibitory concentration: 79700 nM
The estimate for compound 4 lay 1.3-fold (0.10 log units) above the measured number; low and high end bracket the measured number.
By their numbers in this assay, from the lowest: compounds 1, 4, 3 and 2 (each within the scatter of the next).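

In this assay, putting trifluoromethyl in place of chloro on this aromatic carbon, meta to a large group, gives a 1.3-fold lower number from compound 2 to compound 4 (0.13 log units; within the scatter). This is the first step shown at this place in which one group directly replaces another on the same ring position, and the entering group has 4 heavy atoms where chloro has 1. Even this increase in heavy atoms leaves the number within the scatter of the one for chloro, and nothing given here offers an explanation for this result.

The compounds shown leave open whether a different kind of group at this place, such as an amine or a carboxylic acid, would move the number beyond the scatter. They also leave open whether a longer chain here would do so.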